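The source may hold more compounds than are shown below. What is called first, only, known or untested is meant among the compounds shown, and "the series" means these compounds.

Compound 2 `CN(C)C(=O)CN1CCC(c2cc3c(-c4ccc(=O)n(C)c4)ccnc3[nH]2)CC1` is one of three close analogues sharing a single core. In a physicochemical assay for lipophilicity, using the shake flask method, measured as octanol-water partition, at pH 7.4 (a higher number here means a more lipophilic compound, a lower number a more polar compound), compound 2 gives 1.1. Compound 3 `CN(C)C(=O)CN1CCC(c2cc3c(-c4ccc(=O)n(C5CCOCC5)c4)ccnc3[nH]2)CC1` gives 1.1, so that no change at the digits printed from compound 2 to compound 3 (within the scatter). Compound 1 `CC(C)n1nc(-c2ccnc3[nH]c(C4CCN(CC(=O)N(C)C)CC4)cc23)ccc1=O`, the most lipophilic of the three measured, gives 2, and a number 0.90 log units lower from compound 1 to compound 2 (beyond the scatter). Compound 2 thus sits level with compound 3 at the bottom of the measured set and a modest distance below compound 1.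

The next compound, compound 4 `CC(C)n1cc(-c2ccnc3[nH]c(C4CCN(CC(=O)N(C)C)CC4)cc23)cnc1=O`, differs from compound 2 in one place: a group of 10 heavy atoms (7 carbon, 2 nitrogen, 1 oxygen; one six-membered aromatic ring with 2 hetero atoms) in place of a group of 8 heavy atoms (6 carbon, 1 nitrogen, 1 oxygen; one six-membered aromatic ring with 1 hetero atom), on an aromatic carbon. Going by the values given here, the closest measured step is the one between compound 1 and compound 2, which runs in the opposite direction and moved the number by a modest, clearly resolved amount. The step from compound 2 to compound 3 shows that exchanging the group on the ring nitrogen alone left the number unchanged, so the ring itself appears to carry the difference.

Compound 4 is therefore expected to return roughly to the level of compound 1, with an estimated step of a number 0.80 log units higher from compound 2 to compound 4 (beyond the scatter). For compound 4 the expected value in this assay is 1.9, with a range from 1.4 to 2.4.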

Compound 4, distribution coefficient: 0.4
For compound 4 the middle estimate is 1.50 log units above the measured one; measured number below the stated range.
By their numbers in this assay, from the lowest: compound 4; then compounds 2 and 3 (each within the scatter of the next); then compound 1.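

At this position, opposite the ring nitrogen of the shared core, the ring with 2 hetero atoms does not act as one fixed change in this assay: entering compound 2's place, it gives a number 0.70 log units lower from compound 2 to compound 4 (beyond the scatter), the reverse of the direction the earlier step from compound 1 to compound 2 implied. The groups of compound 1 and compound 4 have the same counts of carbon, nitrogen and oxygen and the same kind of ring, yet they give a number 1.60 log units lower from compound 1 to compound 4 (beyond the scatter), so these counts alone do not set the number here, and the arrangement of the atoms within the group is the only thing that separates the two compounds. No supporting information explains this gap.

With only these two arrangements of the ring with 2 hetero atoms, the compounds shown cannot tell which feature of the arrangement carries the gap. They also leave open whether exchanging the group on the ring nitrogen would remain without effect on the ring of compound 4, as it did from compound 2 to compound 3, and how an amine or a carboxylic acid on that ring would read in this assay.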